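Ribose-bearing adenine analogues against bone cancer cell growth

The compounds below may be only part of what the source reports. "The series", "measured", "known", "first", "only" and "open" are said of these compounds alone.

The study follows a series of adenine analogues that carry a sugar and a benzyl-type arm, tested in a functional assay on HOS cells (Homo sapiens) for antiproliferative activity, with a stated time of 72 h; on this read-out higher numbers stand for weaker inhibition and lower numbers for stronger inhibition. Compound 1 `OC[C@H]1O[C@@H](n2cnc3c(NCc4cccc(F)c4)ncnc32)[C@H](O)[C@@H]1O` gave only a limit in this assay, > 166000 nM. Compound 2 `Cc1cccc(CNc2ncnc3c2ncn3[C@@H]2O[C@H](CO)[C@@H](O)[C@H]2O)c1` likewise gave only a limit in this assay, > 166000 nM. A third member, compound 3 `OC[C@H]1O[C@@H](n2cnc3c(NCc4c(F)ccc(F)c4F)ncnc32)[C@H](O)[C@@H]1O`, has no reported result in this assay: compound 3 stands at "not determined" (no result reported). Within the data shown here, the single measured step, a step that the two limits leave unreadable from compound 1 to compound 2, therefore cannot be read as a size, and the only evidence in hand is the limit of > 166000 nM in this assay, at which 2 of the 3 values shown sit.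

Compound 4 `COc1cccc(CNc2ncnc3c2ncn3[C@@H]2O[C@H](CO)[C@@H](O)[C@H]2O)c1O` differs from compound 2 in one place: 2-hydroxy-3-methoxyphenyl in place of 3-methylphenyl on a saturated chain carbon bound to a nitrogen on an aromatic ring. Among the measured compounds shown here, no measured step shows how such a change in the arm affects the read-out, and the two measured compounds sit at the same limit, so there is no basis for expecting either a gain or a loss beyond the usual scatter. The most reasonable expectation is that compound 4 behaves like compound 2, with the step of a number no higher from compound 2 to compound 4 (the limit leaves the size open) expected to be small. Compound 4 is therefore estimated at 166000 nM, within a range from 40000 nM to 600000 nM, and it is expected that this assay may again report only a limit.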

Compound 4, half-maximal inhibitory concentration: > 166000 nM
Compound 4: no number, only a limit; the forecaster's own chance of this, stated with the estimate: 75%; the middle value lies on the limit itself.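

Compound 4 also gave only a limit in this assay, so its steps from compound 1 and from compound 2 cannot be read as sizes, and the picture stays as follows: the limit of > 166000 nM in this assay, at which 3 of the 4 values shown sit.

The compounds shown leave open whether any arm on the shared core can give a readable number in this assay.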